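Aryl substituent change on the shared core: compound 3 to compound 4

The source may hold more compounds than are shown below. What is called first, only, known or untested is meant among the compounds shown, and "the series" means these compounds.

Measured so far in a functional assay on HCT-116 cells (Homo sapiens) for cytotoxicity, read by MTT assay, with a stated time of 48 h; a lower number here means a stronger inhibitor, a higher number a weaker inhibitor:
- compound 1 `Cc1nc2c3ccccc3ccc2c2nc3c(ccc4ccccc43)c(-c3ccccc3Cl)c12`: compound 1 gives 48200 nM
- compound 2 `Cc1nc2c3ccccc3ccc2c2nc3c(ccc4ccccc43)c(C)c12`: compound 2 gives only a limit, > 80000 nM
- compound 3 `Cc1nc2c3ccccc3ccc2c2nc3c(ccc4ccccc43)c(-c3cccc4ccccc34)c12`: compound 3 gives 20800 nM

Compound 3 holds the lowest of the two numbers; compound 1 sits nearest, and compound 2 is known only as a limit (the limit of > 80000 nM in this assay, at which 1 of the 3 values shown sits).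

Compound 4 `Cc1nc2c3ccccc3ccc2c2nc3c(ccc4ccccc43)c(-c3cc(O)nc4ccccc34)c12` differs from compound 3 in one place: 2-hydroxyquinolin-4-yl in place of naphthalen-1-yl on an aromatic carbon. The change keeps a two-ring aryl group at the same position but brings in a ring nitrogen and a hydroxyl.

Within the data shown here, two measured steps touch the same position. Going from compound 1 to compound 3 gave a 2.3-fold lower number from compound 1 to compound 3 (0.36 log units; beyond the scatter), and from compound 2 to compound 3 gave an at least 3.8-fold lower number from compound 2 to compound 3 (0.58 log units; beyond the scatter). Both show that a larger aryl group at this carbon lowers the number, with compound 3 at the low end. Among the measured compounds shown here, no measured step shows what a hydroxyl or ring nitrogen on that aryl group does here.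

For compound 4 the number is therefore expected to stay near that of compound 3, with a step of a 1.4-fold higher number from compound 3 to compound 4 (0.16 log units; within the scatter) in this assay, leaning toward a slightly higher number. Compound 4 is estimated at 30000 nM, with a range from 12000 nM to 75000 nM.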

Compound 4, half-maximal inhibitory concentration: 4630 nM
The estimate for compound 4 lay 6.5-fold (0.81 log units) above the measured number; measured number below the stated range.
By their numbers in this assay, from the lowest: compound 4; then compound 3; then compound 1. At a limit, above all of these: compound 2.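

Notes on the aryl position: in this assay, replacing naphthalen-1-yl with 2-hydroxyquinolin-4-yl gives a 4.5-fold lower number from compound 3 to compound 4 (0.65 log units; beyond the scatter), so the number at this carbon is not set by the presence of a two-ring aryl group alone. The earlier steps shown here linked a lower number only with a change of aryl group, whereas this change keeps a two-ring group and brings in a ring nitrogen and a hydroxyl; against the other substituents, the same group gives a 10-fold lower number from compound 1 to compound 4 (1.02 log units; beyond the scatter) and an at least 17-fold lower number from compound 2 to compound 4 (1.23 log units; beyond the scatter), the second of these being only a floor. Compound 2 is known only as a limit: the limit of > 80000 nM in this assay, at which 1 of the 4 values shown sits.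

Nothing in the data shown gives a cause for the lower number of compound 4. Still open, as far as these compounds go, is whether the hydroxyl or the ring nitrogen accounts for the step from the naphthalen-1-yl compound, and how an amine, a methoxy group or a carboxylic acid in place of that hydroxyl would read at this position.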